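Dropping the Chloro Group: From Compound 2 to Compound 3

The compounds below may be only part of what the source reports. "The series", "measured", "known", "first", "only" and "open" are said of these compounds alone.

Of the compounds shown here, two have been tested in a functional assay on LOX IMVI cells (Homo sapiens) for antiproliferative activity, read by sulforhodamine B assay, with a stated time of 48 h; on this read-out higher numbers stand for weaker inhibition of growth and lower numbers for stronger inhibition of growth. Compound 1 `COc1ccc(OC)c(/C=C/c2nnc(Nc3ccc(Cl)cc3)o2)c1` gives 7910 nM, while compound 2 `COc1ccc(OC)c(/C=C/C(=O)N/N=C/c2ccc(Cl)cc2)c1` gives 254 nM, the lowest of the two numbers, with compound 1 standing beyond the scatter above it. Compound 3 `COc1ccc(OC)c(/C=C/C(=O)N/N=C/c2ccccc2)c1` has not yet been measured. It differs from compound 2 by hydrogen in place of chloro on an aromatic carbon; cut one bond further out, this reads 4-chlorophenyl to phenyl. Going by the values given here, no measured pair shows this change, so the step from compound 2 to compound 3 is only expected, and is guessed to be a modest weakening of about a 1.8-fold higher number from compound 2 to compound 3 (0.25 log units; within the scatter). Compound 3 is therefore estimated at 450 nM, within a range from 150 nM to 1400 nM.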

Compound 3, concentration for 50% growth inhibition: 4110 nM
For compound 3 the middle estimate is 9.1-fold (0.96 log units) below the measured one, outside the stated range (above it).
By their numbers in this assay, from the lowest: compound 2; then compounds 3 and 1 (each within the scatter of the next).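

In this assay the chloro on the aromatic ring of compound 2 turns out to matter a great deal: putting hydrogen in its place gives a 16-fold higher number from compound 2 to compound 3 (1.21 log units; beyond the scatter) in this single pair. This place, para to a large group, is therefore sensitive to what sits on it. Going by these compounds alone, nothing measured so far explains why the chloro counts for so much. Only chloro and hydrogen are shown at this place, so it remains open whether the effect is specific to chloro. A fluoro, a bromo or an amine there could settle that.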